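The source may report more compounds than this note shows. Statements on the series, on what has been measured and on what is new or still open speak of the compounds shown alone.

Working notes on the series in a functional assay on HEK293 cells for negative allosteric modulation of metabotropic glutamate receptor 5 (Rattus norvegicus), read by FLIPR and calcium flux, with a stated time of 170 s; a lower number here means a stronger inhibitor, a higher number a weaker inhibitor. Compound 1 `O=C(Cc1ccccn1)c1cc2n(n1)CCCC2` gives 390 nM in this assay. Compound 2 `N#Cc1ccc(CC(=O)c2cc3n(n2)CCCC3)nc1` gives 53 nM. Compound 3 `COc1cccc(-c2cc3n(n2)CCCC3)c1` gives 4500 nM. Of these three numbers compound 2 holds the lowest; compound 1 stands nearest to it and compound 3 furthest, both gaps beyond the scatter. Within the data shown here, the only single-point step measured so far is a 7.4-fold lower number from compound 1 to compound 2 (0.87 log units; beyond the scatter), a cyano in place of hydrogen on an aromatic carbon.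

Compound 4 `N#Cc1ccc(CC(=O)c2nn3c(c2C#N)CCCC3)nc1` differs from compound 2 by cyano in place of hydrogen on an aromatic carbon. Among the measured compounds shown here, this change sits on the shared core, whereas the step from compound 1 to compound 2 placed its cyano elsewhere in the molecule, so that step is only a loose parallel: it shows that a cyano has been added once with a modest gain, but no measured pair carries a substituent at this position of the core. For the measured compounds named here, with no closer precedent, the expectation for compound 4 is set near compound 2 and given a wide range that allows a move in either direction. In this assay compound 4 is expected to give 80 nM, within 20 nM to 400 nM. The expected step is a 1.5-fold higher number from compound 2 to compound 4 (0.18 log units; within the scatter).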

Compound 4, half-maximal inhibitory concentration: 5380 nM
Beside the measured number, compound 4's estimate is 67-fold (1.83 log units) below it; measured number outside the range, above it.
By their numbers in this assay, from the lowest: compound 2; then compound 1; then compounds 3 and 4 (each within the scatter of the next).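

In this assay, the first substituent placed on this aromatic carbon of the shared core, on the five-membered aromatic ring with 2 nitrogen and next to the ring atom that bears a large group, gives a 100-fold higher number from compound 2 to compound 4 (2.01 log units; beyond the scatter), a large loss of inhibitory strength. The same formal change, cyano in place of hydrogen on an aromatic carbon, elsewhere in the molecule gave a 7.4-fold lower number from compound 1 to compound 2 (0.87 log units; beyond the scatter), so across these two pairs the direction of the step depends on where the cyano sits, and a gain at one place does not carry over to the other. No measurement here bears on the reason for this loss.

The compounds shown leave open whether the loss belongs to cyano itself or to any group at this position, since a smaller substituent such as fluorine or methyl, or an amine, stands on this carbon in none of them. They also leave open whether the core cyano costs as much in the series without the cyano elsewhere in the molecule, the setting of compound 1.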